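Solubility of an oxazole analogue from a thiazole pair

The source may hold more compounds than are shown below. What is called first, only, known or untested is meant among the compounds shown, and "the series" means these compounds.

Measured so far:
compound 1, `CCOC(=O)c1cc(-c2csc(Nc3ccc(C)cc3)n2)on1`: 27700 nM
compound 2, `Cc1ccc(Nc2nc(-c3cc(C(=O)Nc4ccccn4)no3)cs2)cc1`: 2400 nM
compound 3, `CCOC(=O)c1cc(-c2coc(Nc3ccc(C)cc3)n2)on1`: 6800 nM

Of the compounds shown here, three have been measured in a physicochemical assay for solubility, read by LC-MS, in phosphate buffer, measured as kinetic solubility, with a stated time of 4 h, at pH 7.4; a lower number here means a less soluble compound, a higher number a more soluble compound. Compound 1 and compound 2 share one core, and the difference between them is (pyridin-2-yl)amino in place of ethoxy on a carbonyl carbon. That change gave a 12-fold lower number from compound 1 to compound 2 (1.06 log units; beyond the scatter). Compound 3 carries the ethoxycarbonyl group of compound 1 on a different core; the difference between the two cores is not broken down here. In this assay compound 3 stands second highest of the three, with compound 2 giving a lower number and compound 1 a higher one.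

Compound 4, `Cc1ccc(Nc2nc(-c3cc(C(=O)Nc4ccccn4)no3)co2)cc1`, is not yet measured. It differs from compound 3 by (pyridin-2-yl)amino in place of ethoxy on a carbonyl carbon, and the place line reads the same as for the pair of compound 1 and compound 2, so this is the same change made on the core of compound 3. Going by these compounds, the expectation for compound 4 rests on one precedent only, the step from compound 1 to compound 2, and the change to the core is not broken down here, so it is unknown whether that core alters the size of the step. Compound 4 is therefore expected to show a step of about an 11-fold lower number from compound 3 to compound 4 (1.05 log units; beyond the scatter), beside the earlier one, because of a 12-fold lower number from compound 1 to compound 2 (1.06 log units; beyond the scatter) applied to the value of compound 3, 6800 nM. For compound 4 the estimate in this assay is 600 nM, with a likely range from 200 nM to 2000 nM.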

Compound 4, solubility: 9300 nM
Beside the measured number, compound 4's estimate is 16-fold (1.19 log units) below it; the whole stated range lies below it.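

In this assay, putting (pyridin-2-yl)amino in place of ethoxy on a carbonyl carbon gave a 1.4-fold higher number from compound 3 to compound 4 (0.14 log units; within the scatter) on the core of compound 3 and a 12-fold lower number from compound 1 to compound 2 (1.06 log units; beyond the scatter) on the core of compound 1, so the large step seen on one core did not carry over to the other. This shows that, for these two pairs, the same change cannot be assumed to give a step of the same size on a different core, but it does not show which difference between the cores separates the two results, and with a single pair on each core it says nothing about how general either step is. Nothing available bears on why the two steps part, and the result stands here without an explanation.

The compounds shown leave open whether this change on a third core would follow the step on the core of compound 1 or the one on the core of compound 3. They also leave open whether other groups on the same carbonyl carbon, such as dimethylamino, a hydroxyl that would give the carboxylic acid, or a longer butoxy chain, would separate the two cores in the same way.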